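Thiosemicarbazone variants: swapping the aryl ring on the hydrazone

The source may report more compounds than this note shows. Statements on the series, on what has been measured and on what is new or still open speak of the compounds shown alone.

Measured compounds:
Compound 1, `CC1=CC[C@@H]([C@@](C)(O)CCCC(C)(C)NC(=S)NN)CC1` — 15300 nM
Compound 2, `CC1=CC[C@@H]([C@@](C)(O)CCCC(C)(C)NC(=S)N/N=C\c2ccccc2)CC1` — 7720 nM
Compound 3, `CC1=CC[C@@H]([C@@](C)(O)CCCC(C)(C)NC(=S)N/N=C\c2ccc(N(C)C)cc2)CC1` — 14000 nM

In a functional assay on MCF7 cells (Homo sapiens) for cytotoxicity, read by sulforhodamine B assay (a higher number here means a weaker inhibitor of growth, a lower number a stronger inhibitor of growth), compound 1 gives 15300 nM. Compound 2 carries a benzylidene group on the hydrazine end, and in this assay compound 2 gives 7720 nM; the step is a 2.0-fold lower number from compound 1 to compound 2 (0.30 log units; within the scatter). Compound 3 adds a dimethylamino group to that ring and gives 14000 nM, with a 1.8-fold higher number from compound 2 to compound 3 (0.26 log units; within the scatter). All three numbers lie within the scatter of one another, so compound 3 cannot be set apart from either compound 1 or compound 2 on these data.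

Compound 4 is `CC1=CC[C@@H]([C@@](C)(O)CCCC(C)(C)NC(=S)N/N=C\c2ccccc2Cl)CC1`. The change from compound 3 is 2-chlorophenyl in place of 4-(dimethylamino)phenyl on a carbon with a double bond to nitrogen. The step that bears most directly on it is the dimethylamino exchange, a 1.8-fold higher number from compound 2 to compound 3 (0.26 log units; within the scatter), which stayed within the scatter; the larger change of adding the whole ring, a 2.0-fold lower number from compound 1 to compound 2 (0.30 log units; within the scatter), also stayed within it. Going by the values given here, no measured compound carries a chlorine, so the effect of the 2-chlorophenyl ring itself is unknown. Compound 4 is therefore expected to sit close to its neighbours, with the estimated step of a 1.4-fold lower number from compound 3 to compound 4 (0.15 log units; within the scatter) not exceeding the scatter. The estimate for compound 4 is 10000 nM, in the range 4000 nM to 25000 nM.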

Compound 4, concentration for 50% growth inhibition: 31200 nM
Compound 4: the middle estimate sits 3.1-fold (0.49 log units) below what was measured; measured number outside the range, above it.
By their numbers in this assay, from the lowest: compounds 2, 3 and 1 (each within the scatter of the next); then compound 4.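

In this assay, the aryl ring on the hydrazone proves able to move the number beyond the scatter: chloro in place of hydrogen on an aromatic carbon gives a 4.0-fold higher number from compound 2 to compound 4 (0.61 log units; beyond the scatter) and is the largest step in the series. Exchanging 4-(dimethylamino)phenyl for 2-chlorophenyl on a carbon with a double bond to nitrogen also goes beyond the scatter, with a 2.2-fold higher number from compound 3 to compound 4 (0.35 log units; beyond the scatter). Even set against the compound without the aryl ring, the change gives a 2.0-fold higher number from compound 1 to compound 4 (0.31 log units; beyond the scatter), so this ring leaves the compound weaker than the free hydrazine end, and no measurement here accounts for the effect.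

As far as these compounds go, whether a fluoro, bromo or methoxy group on this ring would shift the number in the same direction remains open. So does whether the loss is tied to chlorine itself.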